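The source may report more compounds than this note shows. Statements on the series, on what has been measured and on what is new or still open speak of the compounds shown alone.

Measured compounds:
compound 1 `COc1ccc2[nH]c(-c3ccccc3)c(C=C(C#N)C#N)c2c1` gives 2100 nM
compound 2 `COc1ccc(-c2[nH]c3ccc(OC)cc3c2C=C(C#N)C#N)cc1` gives 503 nM
compound 3 `COc1ccc2[nH]c(-c3ccccc3)c(/C=C(\C#N)S(=O)(=O)c3ccccc3)c2c1` gives 4200 nM

All three numbers come from a functional assay on MDA-MB-468 cells (Homo sapiens) for inhibition, read by sulforhodamine B assay, with a stated time of 48 h; on this read-out lower numbers stand for stronger inhibition of growth and higher numbers for weaker inhibition of growth. Compound 2 and compound 1 differ by hydrogen in place of methoxy on an aromatic carbon, and that step gave a 4.2-fold higher number from compound 2 to compound 1 (0.62 log units; beyond the scatter). The difference between the core of compound 3 and the core of compound 2 is not broken down here. Compound 4 `N#C/C(=C\c1c(-c2ccccc2)[nH]c2ccccc12)S(=O)(=O)c1ccccc1` has not yet been measured in this assay. It differs from compound 3 by hydrogen in place of methoxy on an aromatic carbon, the same kind of change as between compound 2 and compound 1, but at a different place: here the aromatic carbon is part of a fused or bridged system of two rings, meta to a fused ring and para to a fused ring, whereas there it was para to a large group. Because the earlier step gave a 4.2-fold higher number from compound 2 to compound 1 (0.62 log units; beyond the scatter), a step in the same direction is expected, a 1.9-fold higher number from compound 3 to compound 4 (0.28 log units; within the scatter). Compound 4 is therefore estimated at 8000 nM, expected to fall between 2500 nM and 25000 nM.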

Compound 4, concentration for 50% growth inhibition: 1900 nM
Compound 4: middle estimate off by 4.2-fold (0.62 log units), on the high side, outside the stated range (below it).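

In this assay, taking the methoxy off the core of compound 3 gave a 2.2-fold lower number from compound 3 to compound 4 (0.34 log units; beyond the scatter), a change opposite in direction to the earlier step. In this series, then, the effect of this swap did not carry from one core to the other: the same change on two cores in this assay, a 4.2-fold higher number (0.62 log units; beyond the scatter) from compound 2 to compound 1 and a 2.2-fold lower number (0.34 log units; beyond the scatter) from compound 3 to compound 4, 9.2-fold (0.97 log units) apart, beyond the scatter of two such steps. This does not show why the steps differ, since the two pairs differ both in where the methoxy sits and in the rest of the core, and two pairs cannot separate these.

The compounds shown leave open whether a methoxy at the same place on both cores would behave alike. They also leave open whether a hydroxyl, an amine or a fluorine there would follow either step.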